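Restoring a Cycloalkoxy Group on an Amide Inhibitor

The source may hold more compounds than are shown below. What is called first, only, known or untested is meant among the compounds shown, and "the series" means these compounds.

Compound 1, `COc1ccc(C(=O)Nc2ccccc2Br)cc1OC1CCCC1`: 130 nM
Compound 2, `COc1ccc(C(=O)Nc2c(F)cccc2F)cc1`: 37000 nM

In an assay on isolated protein for inhibition of phosphodiesterase 4A (Sus scrofa) (on this read-out lower numbers stand for stronger inhibition and higher numbers for weaker inhibition), compound 1 gives 130 nM and compound 2 gives 37000 nM. Compound 2 therefore stands at the highest number of the two measured, and its distance from compound 1 is far beyond the usual scatter. Compound 3, `COc1ccc(C(=O)Nc2c(F)cccc2F)cc1OC1CCCCC1`, differs from compound 2 in one place: cyclohexyloxy in place of hydrogen on an aromatic carbon. Going by the values given here, no measured pair differs in only this place, so the size of the step has to be judged from compound 1, which also carries a cycloalkoxy group on its shared core but a differently substituted amide ring. The expected step is a 120-fold lower number from compound 2 to compound 3 (2.09 log units; beyond the scatter), a large fall well beyond the scatter, because compound 1 gives 130 nM. Compound 3 is accordingly estimated at 300 nM, with a plausible range from 50 nM to 2000 nM.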

Compound 3, half-maximal inhibitory concentration: 400 nM
Beside the measured number, compound 3's estimate is 1.3-fold (0.12 log units) below it, and the stated range covers the measured number.
By their numbers in this assay, from the lowest: compound 1; then compound 3; then compound 2.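

In this assay, cyclohexyloxy in place of hydrogen on this aromatic carbon, ortho to a methoxy group, gives a 93-fold lower number from compound 2 to compound 3 (1.97 log units; beyond the scatter), a large change. Going by these compounds alone, these two compounds differ in this one place only, with the amide ring kept the same, so the whole step can be tied to this single change for the first time. Nothing measured here explains why adding this group makes such a large difference. On these data alone, whether an open chain such as butoxy, or an amine, on the same carbon would give a step of similar size remains open. The compounds shown also include no pair that changes only the ring on the amide, so the effect of that ring on this read-out cannot yet be separated out.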